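The source may hold more compounds than are shown below. What is called first, only, known or untested is meant among the compounds shown, and "the series" means these compounds.

In an assay on ileum (strain Hartley) with 5-hydroxytryptamine receptor 3A (Cavia porcellus) as the target (a lower number here means a smaller maximal response, a higher number a larger maximal response), compound 1 `Cc1cc(Cl)c2oc(N3CCN(C)CC3)nc2c1` gives 0.26, the lowest of the three numbers recorded there. Its nearest neighbour is compound 2 `Cc1cc(C)c2oc(N3CCN(C)CC3)nc2c1`, which in this assay gives 0.62, and furthest from it stands compound 3 `CN1CCN(c2nc3cc(N)ccc3o2)CC1`, which in this assay gives 0.76. For the measured compounds named here, the step measured between the first two, a number 0.36 higher from compound 1 to compound 2 (beyond the scatter), is the one measured change that bears on what follows.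

Compound 4 `CN1CCN(c2nc3cc(Cl)cc(Cl)c3o2)CC1` has not yet been measured in this assay. It differs from compound 1 by chloro in place of methyl on an aromatic carbon. The change runs opposite to the measured step: there, methyl in place of chloro on an aromatic carbon raised the maximal response by a large amount, beyond the scatter. Here chloro enters in place of methyl, at a carbon meta to a chloro group, so the same relation, read in reverse, points toward a smaller maximal response, although compound 1 already sits low and the response cannot fall far.

Compound 4 is therefore expected to show a step of a number 0.14 lower from compound 1 to compound 4 (beyond the scatter) in this assay. The estimate for compound 4 in this assay is 0.12, with a range from 0.02 to 0.3.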

Compound 4, intrinsic activity: the largest response reached, as a fraction of the reference agonist's: 0.14
For compound 4 the middle estimate is 0.020 below the measured one; low and high end bracket the measured number.
By their numbers in this assay, from the lowest: compound 4; then compound 1; then compound 2; then compound 3.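

The step a number 0.12 lower from compound 1 to compound 4 (beyond the scatter) shows in this assay that the carbon meta to a chloro group, which carries the methyl group in compound 1, also responds to an exchange of methyl and chloro. Until now, that exchange had been read only at the carbon carrying the chloro group in compound 1, through the step a number 0.36 higher from compound 1 to compound 2 (beyond the scatter). For the compounds shown here, at both carbons the compound with chloro gives the lower maximal response and the compound with methyl the higher, and no compound that tests this goes against it, while compound 3 differs from the others in more than one place and cannot test it. The step here is modest and the earlier one large, but nothing available accounts for either step or for the difference in their size.

The compounds shown leave open whether this trend extends beyond methyl and chloro at this carbon, for example to a methoxy group, a trifluoromethyl group or a carboxylic acid. They also leave open whether an unsubstituted carbon at this position would give a maximal response closer to that of compound 1 or to that of compound 4.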